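A Methoxyphenyl Variant in a Sulfonamide Series

The source may hold more compounds than are shown below. What is called first, only, known or untested is meant among the compounds shown, and "the series" means these compounds.

Three members of one sulfonamide series have been measured in a functional assay on Capan-2 cells (Homo sapiens) for inhibition, read by MTT assay, with a stated time of 72 h; on this read-out higher numbers stand for weaker inhibition of growth and lower numbers for stronger inhibition of growth. Compound 1 `CC(C)(C)c1ccc(CNCCCNS(=O)(=O)c2cc(C(F)(F)F)cc(C(F)(F)F)c2)cc1` gives 2100 nM, compound 2 `COc1cccc(CNCCCNS(=O)(=O)c2cc(C(F)(F)F)cc(C(F)(F)F)c2)c1` gives 6400 nM, and compound 3 `O=S(=O)(NCCCNCc1ccc(Cl)c(C(F)(F)F)c1)c1cc(C(F)(F)F)cc(C(F)(F)F)c1` gives 9100 nM. Within the data shown here, of the three numbers, that of compound 3 is the largest, but only the step of a 4.3-fold higher number from compound 1 to compound 3 (0.64 log units; beyond the scatter) lies beyond the scatter; the step of a 1.4-fold higher number from compound 2 to compound 3 (0.15 log units; within the scatter) stays within it, so compound 3 and compound 2 cannot be told apart.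

Compound 4 `COc1ccccc1CNCCCNS(=O)(=O)c1cc(C(F)(F)F)cc(C(F)(F)F)c1` is not yet measured. It differs from compound 3 in one place: 2-methoxyphenyl in place of 4-chloro-3-(trifluoromethyl)phenyl on a saturated chain carbon bound to an amine nitrogen. Among the measured compounds shown here, no measured step makes this exact exchange. The closest guides are the step of a 1.4-fold higher number from compound 2 to compound 3 (0.15 log units; within the scatter), in which a methoxyphenyl was exchanged for the 4-chloro-3-(trifluoromethyl)phenyl without moving beyond the scatter, and the step of a 3.0-fold higher number from compound 1 to compound 2 (0.48 log units; beyond the scatter), which ended at a methoxyphenyl and was modest. The step of a 1.7-fold lower number from compound 3 to compound 4 (0.22 log units; within the scatter) is therefore expected to stay within the scatter. Compound 4 is expected to give 5500 nM in this assay, with a range from 2000 nM to 15000 nM.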

Compound 4, concentration for 50% growth inhibition: 6000 nM
The estimate for compound 4 lay 1.1-fold (0.04 log units) below the measured number; the measured number falls inside the stated range.
By their numbers in this assay, from the lowest: compound 1; then compounds 4, 2 and 3 (each within the scatter of the next).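

With the methoxy group on this saturated chain carbon bound to an amine nitrogen, the 2-methoxyphenyl and 3-methoxyphenyl cannot be told apart in this assay (a 1.1-fold lower number from compound 2 to compound 4 (0.03 log units; within the scatter)), so the new result shows no preference between these two methoxyphenyl forms. The 2-methoxyphenyl also cannot be told apart from the larger 4-chloro-3-(trifluoromethyl)phenyl (a 1.5-fold lower number from compound 3 to compound 4 (0.18 log units; within the scatter)), although the exchange changes the heavy-atom count and adds a hydrogen-bond acceptor. Among the four compounds, only the 4-(tert-butyl)phenyl stands apart, and the step to the 2-methoxyphenyl lies beyond the scatter (a 2.9-fold higher number from compound 1 to compound 4 (0.46 log units; beyond the scatter)). Nothing available explains these numbers.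

The compounds shown leave open where a 4-methoxyphenyl or an unsubstituted phenyl would fall. They also leave open whether a longer chain between the two nitrogens would keep this pattern.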